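Tail changes on a shared core with modest effect

The source may hold more compounds than are shown below. What is called first, only, known or untested is meant among the compounds shown, and "the series" means these compounds.

Three compounds share one core and differ only in the chain attached to one ring nitrogen. Compound 1 `CC(C)(N)C(=O)N[C@H](COCc1ccccc1)c1nnnn1CCCCCNS(C)(=O)=O` gives in a functional assay on H4 cells for agonist activity at growth hormone secretagogue receptor type 1 (Homo sapiens), read by FLIPR (on this read-out higher numbers stand for an effect only at larger amounts of compound and lower numbers for an effect already at smaller amounts), a value of 75 nM. Compound 2 `CC(C)(N)C(=O)N[C@H](COCc1ccccc1)c1nnnn1CCCCC#N` gives 35 nM in this assay. Compound 3 `CCCCNC(=O)CCn1nnnc1[C@@H](COCc1ccccc1)NC(=O)C(C)(C)N` gives 42 nM in this assay. On these numbers compound 3 sits between the other two, and its gaps to both lie within the usual spread of repeated measurements. The measured steps show how the far end of this chain behaves: a 2.1-fold lower number from compound 1 to compound 2 (0.33 log units; beyond the scatter); a 1.8-fold lower number from compound 1 to compound 3 (0.25 log units; within the scatter); a 1.2-fold higher number from compound 2 to compound 3 (0.08 log units; within the scatter). Compound 4 `CC(C)(N)C(=O)N[C@H](COCc1ccccc1)c1nnnn1CCC(=O)NCCCc1ccccc1` takes the next step: phenyl in place of methyl on a saturated chain carbon, three bonds along the chain from an amide-type nitrogen. Within the data shown here, none of the measured steps makes this exact exchange, but all three alter the outer part of the same chain, and only one of them moved the number beyond the scatter, and then only modestly. The expectation is therefore a small change at most in this assay, with no clear direction, expressed as a 1.1-fold lower number from compound 3 to compound 4 (0.02 log units; within the scatter). Compound 4 is expected to give about 40 nM in this assay, within a range from 15 nM to 110 nM.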

Compound 4, half-maximal effective concentration: 59 nM
Compound 4: middle estimate off by 1.5-fold (0.17 log units), on the low side; the measured number falls inside the stated range.
By their numbers in this assay, from the lowest: compounds 2, 3, 4 and 1 (each within the scatter of the next, the first and the last beyond it).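

Replacing the terminal methyl of the butyl group with phenyl turns the butyl on the amide into 3-phenylpropyl and brings a six-membered aromatic ring to this chain, which none of the earlier chains carried; in this assay this change gives a 1.4-fold higher number from compound 3 to compound 4 (0.15 log units; within the scatter) and so makes no readable difference. Measured against the two other chains, compound 4 gives the same picture, with a 1.7-fold higher number from compound 2 to compound 4 (0.23 log units; within the scatter) and a 1.3-fold lower number from compound 1 to compound 4 (0.10 log units; within the scatter), so the larger group at this place sits among the earlier tails without separating from any of them, and the step from compound 1 to compound 2 remains the only one beyond the scatter. Nothing in the available data explains why this added ring leaves the number so little changed.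

The compounds shown leave open whether a ring held closer to the amide, as a benzyl or phenethyl group in place of 3-phenylpropyl, would behave in the same way. They also leave open what a chain ending in an amine or a carboxylic acid would do in this assay, since every tail here ends in a nitrile, a sulfonamide, an alkyl group or a phenyl ring.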